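The source may report more compounds than this note shows. Statements on the series, on what has been measured and on what is new or still open speak of the compounds shown alone.

The three measured compounds and their numbers in an assay on isolated protein for inhibition of acyl-CoA:cholesterol acyltransferase (Oryctolagus cuniculus); on this read-out higher numbers stand for weaker inhibition and lower numbers for stronger inhibition:

Compound 1, `CCCCCCc1ccc(NC(=O)Nc2c(C(C)C)cccc2C(C)C)cc1`, gives 26 nM in this assay.
Compound 2, `CCCCCCCc1ccc(NC(=O)Nc2c(C(C)C)cccc2C(C)C)cc1`, gives 19 nM in this assay.
Compound 3, `CCCCCCCCCCc1ccc(NC(=O)Nc2c(C(C)C)cccc2C(C)C)cc1`, gives 13 nM in this assay.

Compound 2 stands second highest of these three numbers. Its nearer neighbour is reached by a 1.4-fold lower number from compound 1 to compound 2 (0.14 log units; within the scatter) and its further neighbour by a 1.5-fold lower number from compound 2 to compound 3 (0.16 log units; within the scatter), so both of its steps lie within the scatter, and the three compounds cannot be ordered against one another on this read-out.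

Compound 4, `CCCCCCCCCCCc1ccc(NC(=O)Nc2c(C(C)C)cccc2C(C)C)cc1`, has not yet been measured. It differs from compound 2 in one place: butyl in place of hydrogen on a saturated chain carbon, seven bonds along the chain from an aromatic carbon. Among the compounds with values here, three measured steps bear on this change. The closest in kind is a 1.5-fold lower number from compound 2 to compound 3 (0.16 log units; within the scatter), a smaller addition at the same place; the same group entering one bond nearer the ring gives a 2.0-fold lower number from compound 1 to compound 3 (0.30 log units; within the scatter); and the smallest lengthening gives a 1.4-fold lower number from compound 1 to compound 2 (0.14 log units; within the scatter). Each of these lowers the number, yet none reaches beyond the scatter. For compound 4 a step of a 1.6-fold lower number from compound 2 to compound 4 (0.20 log units; within the scatter) toward a lower number is therefore expected, again within the scatter rather than beyond it. Compound 4 is estimated at 12 nM in this assay, with a range from 5 nM to 30 nM.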

Compound 4, half-maximal inhibitory concentration: 9 nM
Beside the measured number, compound 4's estimate is 1.3-fold (0.12 log units) above it; measured number inside the range.
By their numbers in this assay, from the lowest: compounds 4, 3, 2 and 1 (each within the scatter of the next, the first and the last beyond it).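

In this assay, within the data shown here, lengthening the chain now gives steps beyond the scatter, which none of the earlier steps did: butyl in place of hydrogen on a saturated chain carbon, seven bonds along the chain from an aromatic carbon, gives a 2.1-fold lower number from compound 2 to compound 4 (0.32 log units; beyond the scatter), and pentyl in place of hydrogen, six bonds along the chain, gives a 2.9-fold lower number from compound 1 to compound 4 (0.46 log units; beyond the scatter). Methyl in place of hydrogen on a saturated chain carbon gives only a 1.4-fold lower number from compound 3 to compound 4 (0.16 log units; within the scatter), and this small addition matches the earlier methyl step: the same change on two cores in this assay, a 1.4-fold lower number (0.14 log units; within the scatter) from compound 1 to compound 2 and a 1.4-fold lower number (0.16 log units; within the scatter) from compound 3 to compound 4, 1.1-fold (0.02 log units) apart, within the scatter of two such steps The butyl step agrees in the same way with the earlier butyl step, so the two larger additions also give closely matching results on the two cores: the same change on two cores in this assay, a 2.0-fold lower number (0.30 log units; within the scatter) from compound 1 to compound 3 and a 2.1-fold lower number (0.32 log units; beyond the scatter) from compound 2 to compound 4, 1.1-fold (0.02 log units) apart, within the scatter of two such steps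

The compounds shown leave open whether a longer chain than that of compound 4 would lower the number further or whether the series would level off. They also leave open how a branched chain, or a chain ending in an amine or a carboxylic acid, would read in this assay.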